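The compounds below may be only part of what the source reports. "The series", "measured", "known", "first", "only" and "open" are said of these compounds alone.

Working notes on the series.

The series shares one core, varied only in the group on the triazole nitrogen. Compound 1 `COc1ccccc1-n1cc(COc2c(/C=C\C(=O)O)ccc(OC)c2CC=C(C)C)nn1` carries a 2-methoxyphenyl there and in a functional assay on HCT-116 cells (Homo sapiens) for cytotoxicity, read by MTT assay, with a stated time of 24 h (on this read-out higher numbers stand for weaker inhibition and lower numbers for stronger inhibition), compound 1 gives 32200 nM. Compound 2 `COc1ccc(-n2cc(COc3c(/C=C\C(=O)O)ccc(OC)c3CC=C(C)C)nn2)cc1` carries a 4-methoxyphenyl and in this assay compound 2 gives 8700 nM, a step of a 3.7-fold lower number from compound 1 to compound 2 (0.57 log units; beyond the scatter). Compound 3 `COc1ccc(/C=C\C(=O)O)c(OCc2cn(-c3ccccc3I)nn2)c1CC=C(C)C` carries a 2-iodophenyl and in this assay compound 3 gives 23100 nM; it stands second highest of the three numbers, with compound 1 nearest (a 1.4-fold lower number from compound 1 to compound 3 (0.14 log units; within the scatter)) and compound 2 furthest (a 2.7-fold higher number from compound 2 to compound 3 (0.42 log units; beyond the scatter)).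

Compound 4 `COc1ccc(/C=C\C(=O)O)c(OCc2cn(-c3ccccc3C#N)nn2)c1CC=C(C)C` differs from compound 3 by cyano in place of iodo on an aromatic carbon. Among the compounds with values here, the one step that bears on it is the swap of the group at the same place, from compound 1 to compound 3, which stayed within the scatter. Within the data shown here, no step with cyano exists. The expectation for this assay is therefore a step of a 1.0-fold higher number from compound 3 to compound 4 (0.02 log units; within the scatter), not beyond the scatter. Compound 4 is estimated at 24000 nM, between 9000 nM and 60000 nM.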

Compound 4, half-maximal inhibitory concentration: 38300 nM
Compound 4: middle estimate off by 1.6-fold (0.20 log units), on the low side; low and high end bracket the measured number.
By their numbers in this assay, from the lowest: compound 2; then compounds 3, 1 and 4 (each within the scatter of the next).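

In this assay, cyano in place of iodo gives a 1.7-fold higher number from compound 3 to compound 4 (0.22 log units; within the scatter) and cyano in place of methoxy gives a 1.2-fold higher number from compound 1 to compound 4 (0.08 log units; within the scatter), so methoxy, iodo and cyano on the aromatic carbon ortho to a large group all lie within the scatter of one another. Within the data shown here, compound 2 stays apart from this group, with a 4.4-fold higher number from compound 2 to compound 4 (0.64 log units; beyond the scatter) as the widest step so far. Nothing in hand bears on why the numbers fall this way.

Among these compounds, compound 2 is the only member with its group elsewhere on the ring, so one 4-methoxyphenyl compound must carry any reading of the change in position. From the compounds shown here alone, whether an amine, a carboxylic acid or a longer chain at the ortho place would move the number beyond the scatter also stays open.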